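A few compounds are considered here, and "the series" means these few. Any claim that something is new, unique, unknown or untested is made for them only; others in the source may bear on it.

Compound 1 `O=C1CN(C2CCCC2)c2nc(Nc3ccc(N4CCCCC4)cc3)ncc2N1`: in a functional assay on MDA-MB-231 cells (Homo sapiens) for inhibition, read by MTT assay, with a stated time of 48 h (a lower number here means a stronger inhibitor, a higher number a weaker inhibitor), compound 1 gives 25000 nM.
Compound 2 `CN1CCN(c2ccc(Nc3ncc4c(n3)N(C3CCCC3)CC(=O)N4)nc2)CC1`: for compound 2 the result in this assay is only a limit, > 30000 nM.

Compound 2 thus stands at the limit of this assay and not at a number, as the limit of > 30000 nM in this assay, at which 1 of the 2 values shown sits, records. Compound 3 `O=C1CN(C2CCCC2)c2nc(Nc3ccc(N4CCCCC4)cn3)ncc2N1` is reached from compound 2 by one change: piperidin-1-yl in place of 4-methylpiperazin-1-yl on an aromatic carbon. Going by the values given here, no measured pair shows this change. Compound 1 reads 25000 nM, which gives the only numbered anchor in this set. For the step from compound 2 to compound 3 an expected move of an at least 1.2-fold lower number from compound 2 to compound 3 (0.07 log units; that floor lies within the scatter) is estimated, not clearly beyond the scatter. Compound 3 is therefore expected at about 25000 nM, with a range from 10000 nM to 60000 nM.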

Compound 3, half-maximal inhibitory concentration: > 30000 nM
Compound 3 gave a limit, no number; the forecaster's own chance of this, stated with the estimate: 40%; at least 1.2-fold (0.07 log units) between middle value and limit.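

No step can be read from compound 2 to compound 3, as both stop at the same limit and give no number: the limit of > 30000 nM in this assay, at which 2 of the 3 values shown sit.

On these data alone, whether piperidin-1-yl in place of 4-methylpiperazin-1-yl changes the inhibition at all stays open.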